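A Chlorinated Chain Replaces an Aromatic Sulfanyl Group

A few compounds are considered here, and "the series" means these few. Any claim that something is new, unique, unknown or untested is made for them only; others in the source may bear on it.

In a functional assay on RPMI-8226 cells (Homo sapiens) for cytotoxicity, read by MTT assay, with a stated time of 72 h (on this read-out higher numbers stand for weaker inhibition and lower numbers for stronger inhibition), compound 1 `C=C1C2=C(C(=O)N1OC)[C@H](OC(=O)CSc1nc3ccccc3o1)[C@@](C)(O)[C@H](CCCCC)O2` gives 5100 nM. This is the higher of the two numbers available, which makes it the weaker inhibitor of the pair, since compound 2 `C=C1C2=C(C(=O)N1OC)[C@H](OC(=O)CSc1nc3ccccc3s1)[C@@](C)(O)[C@H](CCCCC)O2` gives 2000 nM. The next structure, compound 3 `C=C1C2=C(C(=O)N1OC)[C@H](OC(=O)CCCCCl)[C@@](C)(O)[C@H](CCCCC)O2`, has not yet been measured. It keeps the shared core of compound 1 and differs in one place: 3-chloropropyl in place of (1,3-benzoxazol-2-yl)sulfanyl on a saturated chain carbon bound to a carbonyl carbon. Within the data shown here, the only measured step is a 2.6-fold lower number from compound 1 to compound 2 (0.41 log units; beyond the scatter), a modest change. That step exchanges one aromatic group for another, whereas compound 3 loses the sulfur and both rings, so it offers only a rough guide to size and none to direction. Among the measured compounds shown here, no measured compound carries a 3-chloropropyl group. A shift beyond the usual scatter is therefore not expected, although the uncertainty is wide. The expected step is a 1.3-fold lower number from compound 1 to compound 3 (0.11 log units; within the scatter). Compound 3 is estimated at 4000 nM, with an expected range of 1200 nM to 14000 nM.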

Compound 3, half-maximal inhibitory concentration: 4300 nM
Beside the measured number, compound 3's estimate is 1.1-fold (0.03 log units) below it; the measured number falls inside the stated range.
By their numbers in this assay, from the lowest: compound 2; then compounds 3 and 1 (each within the scatter of the next).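

At this saturated chain carbon bound to a carbonyl carbon, this assay does not separate two very different groups: (1,3-benzoxazol-2-yl)sulfanyl, with its two aromatic rings, and 3-chloropropyl, with no ring, give a 1.2-fold lower number from compound 1 to compound 3 (0.07 log units; within the scatter) and so stand level. The same exchange starting from compound 2, which carries (1,3-benzothiazol-2-yl)sulfanyl, does register, with a 2.2-fold higher number from compound 2 to compound 3 (0.33 log units; beyond the scatter) as a modest step, and this leaves compound 2 the strongest of the three. Carrying aromatic rings at this place is therefore not enough on its own to separate a compound from the ring-free chain, as compound 1 shows, and among the groups shown only (1,3-benzothiazol-2-yl)sulfanyl stands apart.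

Nothing available explains why these groups compare as they do. From the compounds shown here alone, whether a longer chlorinated chain, a chain ending in an amine or a carboxylic acid, or a simple phenyl group on the sulfur would match compound 2 or stand level with compounds 1 and 3 remains open, and a single chlorinated compound cannot show whether the chlorine itself matters.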